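The source may report more compounds than this note shows. Statements on the series, on what has been measured and on what is new or still open speak of the compounds shown alone.

Compound 3 `CCOC(=O)COc1cc(=O)oc2cc(OCc3cccc(Cl)c3)ccc12` gives 0% in an assay on isolated protein (strain Sprague-Dawley) for inhibition of Amine oxidase [flavin-containing] A (Rattus norvegicus), read by spectrophotometry, with a stated time of 5 min, tested at 10 uM; on this read-out lower numbers stand for less inhibition and higher numbers for more inhibition at the one concentration tested (going by the name of the read-out). It stands level with compound 1 `O=c1cc(O)c2ccc(OCc3cccc(F)c3)cc2o1`, which gives 0% in this assay; together these are the lowest of the three numbers. Compound 2 `COc1cc(=O)oc2cc(OCc3cccc(F)c3)ccc12` gives 49% in this assay and lies well beyond the scatter above both.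

Among the compounds with values here, the single measured step is a number 49 percentage points higher from compound 1 to compound 2 (beyond the scatter), a change of methyl in place of hydrogen on an oxygen on an aromatic ring. Compound 4 `NC(=O)c1cc(=O)oc2cc(OCc3cccc(Cl)c3)ccc12` differs from compound 3 by carbamoyl in place of (ethoxycarbonyl)methoxy on an aromatic carbon. Within the data shown here, no measured step exchanges a (ethoxycarbonyl)methoxy for a carbamoyl, so the step from compound 1 to compound 2 bears only loosely, showing that a change at this part of the core can shift the read-out by a large amount in either sense; compound 3 itself, with a larger group than compound 2, sits at the bottom. The expected step is therefore small and upward, within the scatter, a number 15 percentage points higher from compound 3 to compound 4 (beyond the scatter). Compound 4 is estimated at 15%, in the range 0% to 45%.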

Compound 4, a percentage reported as inhibition, at one concentration (the size of the read-out at that concentration, not a potency): 14%
The estimate for compound 4 lay 1 percentage points above the measured number; low and high end bracket the measured number.
By their numbers in this assay, from the lowest: compounds 1 and 3 (each within the scatter of the next); then compound 4; then compound 2.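

Placing carbamoyl in place of (ethoxycarbonyl)methoxy on this aromatic carbon gives a number 14 percentage points higher from compound 3 to compound 4 (beyond the scatter) in this assay. This shows that a group joined to the ring through carbon, rather than through oxygen as in the methyl step, can also raise the read-out at this position. Within the data shown here, the rise is modest next to a number 49 percentage points higher from compound 1 to compound 2 (beyond the scatter), but that step belongs to the fluorine-bearing pair and this one to the chlorine-bearing pair, so the two show only that both changes raise the number.

The exchange alters the link, the heavy-atom count and the hydrogen-bond donor count together, and no measurement available here separates these or explains the step. Open, from the compounds shown here alone, is how a carboxylic acid, an amine or a methoxy group on the chlorine-bearing compound would read at this position.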